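Dimethoxyphenyl isomers on the carbonyl carbon

The compounds below may be only part of what the source reports. "The series", "measured", "known", "first", "only" and "open" are said of these compounds alone.

In a functional assay on a cell-free system (Platelet, plasma, Homo sapiens) for inhibition (on this read-out lower numbers stand for stronger inhibition and higher numbers for weaker inhibition), compound 1 `Cc1ccc(N(CCN2CCC(OCC(=O)O)CC2)C(=O)c2ccc(F)cc2)cc1` gives 970 nM. Compound 2 `COc1ccc(OC)c(C(=O)N(CCN2CCC(OCC(=O)O)CC2)c2ccc(C)cc2)c1` gives > 3000 nM, which is a limit and not a number.

Compound 3 `COc1ccc(C(=O)N(CCN2CCC(OCC(=O)O)CC2)c2ccc(C)cc2)cc1OC` differs from it by 3,4-dimethoxyphenyl in place of 2,5-dimethoxyphenyl on a carbonyl carbon, with 3,4-dimethoxyphenyl in place of 2,5-dimethoxyphenyl on a carbonyl carbon. Within the data shown here, the only measured step that bears on this is an at least 3.0-fold higher number from compound 1 to compound 2 (0.49 log units; beyond the scatter), so the group at this place can shift the read-out beyond the scatter. A modest move toward lower numbers in this assay is therefore expected, though another limit reading remains possible. The expected size is an at least 1.5-fold lower number from compound 2 to compound 3 (0.17 log units; that floor lies within the scatter). Compound 3 is estimated at 2000 nM, with a range of 600 nM to 6000 nM.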

Compound 3, half-maximal inhibitory concentration: > 3000 nM
Compound 3 ended at the assay's limit; the forecaster's own chance of this, stated with the estimate: 45%; at least 1.5-fold (0.17 log units) between middle value and limit.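

Moving from 2,5-dimethoxyphenyl to 3,4-dimethoxyphenyl on a carbonyl carbon does not bring this assay into a readable range: compound 3 gives > 3000 nM, a limit and not a number. Against the 4-fluorophenyl group, the change gives an at least 3.0-fold higher number from compound 1 to compound 3 (0.49 log units; beyond the scatter), so this second dimethoxyphenyl isomer also loses ground beyond the scatter. The step between the two isomers cannot be read, and any difference between them stays hidden: the limit of > 3000 nM in this assay, at which 2 of the 3 values shown sit.

As far as these compounds go, how far either isomer lies past the limit remains open. Also open, from the compounds shown here alone, is whether a phenyl carrying a single methoxy group or a chlorine would stay close to compound 1.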